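The source may hold more compounds than are shown below. What is called first, only, known or untested is meant among the compounds shown, and "the series" means these compounds.

Measured compounds:
compound 1 `COc1cccc(NC(=O)COc2ccc3cc(/C=C4/SC(=O)NC4=O)ccc3c2)c1` — 1600 nM
compound 2 `O=C(COc1ccc2cc(/C=C3/SC(=O)NC3=O)ccc2c1)Nc1ccc(F)cc1F` — 3900 nM

In an assay on isolated protein for inhibition of histone deacetylase 4 (Homo sapiens), with a stated time of 1 h (on this read-out higher numbers stand for weaker inhibition and lower numbers for stronger inhibition), compound 2 holds the highest of the two numbers; its nearest neighbour is compound 1, and the step of a 2.4-fold higher number from compound 1 to compound 2 (0.39 log units; beyond the scatter) is modest. Compound 3 `O=C(COc1ccc2cc(/C=C3/SC(=O)NC3=O)ccc2c1)Nc1ccccc1` differs from compound 2 by phenyl in place of 2,4-difluorophenyl on an amide-type nitrogen. Among the measured compounds shown here, only that single step touches this aryl group, and it shows a modest change when the substitution pattern on it is exchanged; a plain phenyl is expected to sit near or somewhat below compound 2. Compound 3 is estimated at 2500 nM (range 1000 nM to 6000 nM), an expected step of a 1.6-fold lower number from compound 2 to compound 3 (0.19 log units; within the scatter).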

Compound 3, half-maximal inhibitory concentration: 2100 nM
For compound 3 the middle estimate is 1.2-fold (0.08 log units) above the measured one; the measured number falls inside the stated range.
By their numbers in this assay, from the lowest: compounds 1, 3 and 2 (each within the scatter of the next, the first and the last beyond it).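

Phenyl in place of 2,4-difluorophenyl on the amide-type nitrogen gives a 1.9-fold lower number from compound 2 to compound 3 (0.27 log units; within the scatter) in this assay and hydrogen in place of methoxy on an aromatic carbon gives a 1.3-fold higher number from compound 1 to compound 3 (0.12 log units; within the scatter) on this read-out. The unsubstituted phenyl therefore cannot be told apart from either substituted aryl group, although a 2.4-fold higher number from compound 1 to compound 2 (0.39 log units; beyond the scatter) is beyond the scatter. No available evidence bears on these steps.

Still open, as far as these compounds go, is whether an amine or a carboxylic acid on the phenyl would move the number beyond the scatter from compound 3. From the compounds shown here alone, a longer chain between the amide-type nitrogen and the phenyl also remains open.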